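The source may hold more compounds than are shown below. What is called first, only, known or untested is meant among the compounds shown, and "the series" means these compounds.

In a functional assay on MDBK cells (Bos taurus) for cytotoxicity (a lower number here means that less compound is tolerated, a higher number that more compound is tolerated), compound 1 `C=CCO/N=C(\C#N)C(=O)NCC1=NOC(c2ccccc2)C1` gives 100 ug/mL. Compound 2 `CCO/N=C(\C#N)C(=O)NCC1=NOC(C(C)(C)C)C1` reads > 100 ug/mL, which is a limit and not a number. Compound 3 `C=CCO/N=C(\C#N)C(=O)NCC1=NOC(C(C)(C)C)C1` reads > 100 ug/mL, again only a limit, so its true position is open. Going by the values given here, the values so far are dominated by the limit of > 100 ug/mL in this assay, at which 2 of the 3 values shown sit.

Compound 4 `C=CCO/N=C(\CC)C(=O)NCC1=NOC(C(C)(C)C)C1` has not been measured. It differs from compound 3 as follows: ethyl in place of cyano on a carbon with a double bond to nitrogen. In words, this is ethyl in place of cyano on a carbon with a double bond to nitrogen.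

Two measured steps exist, a number no lower from compound 1 to compound 3 (the limit leaves the size open) and a step that the two limits leave unreadable from compound 2 to compound 3. Neither has a readable size, and neither changes this place. No step beyond the scatter is therefore expected, and the expected step is a number no higher from compound 3 to compound 4 (the limit leaves the size open). The estimate for compound 4 is 100 ug/mL, with an expected range from 50 ug/mL to 200 ug/mL.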

Compound 4, half-maximal cytotoxic concentration: > 100 ug/mL
Compound 4 ended at the assay's limit (the forecaster's own chance of this, stated with the estimate: 60%); the middle value sits exactly at the limit.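

Going by these compounds alone, the readings of compound 3 and compound 4 in this assay are both limits and not numbers, and no step between them can be read. The compounds shown leave open whether ethyl in place of cyano changes the tolerated concentration at all, as most readings rest on a single limit: the limit of > 100 ug/mL in this assay, at which 3 of the 4 values shown sit.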